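The compounds below may be only part of what the source reports. "The series", "measured", "known", "first", "only" and "open" are said of these compounds alone.

Of the compounds shown here, three have so far been measured in an assay on isolated protein for inhibition of cathepsin S (Homo sapiens), read by fluorescence, with a stated time of 20 min; on this read-out higher numbers stand for weaker inhibition and lower numbers for stronger inhibition. Compound 1 `N#CCNC(=O)[C@@H]1CC(F)(F)C[C@H]1C(=O)N1CCOCC1` gives 830 nM. Compound 2 `N#CCNC(=O)[C@@H]1C[C@@H](S(=O)(=O)c2ccccc2Cl)C[C@H]1C(=O)N1CCOCC1` gives 0.5 nM. Compound 3 `C[C@@H]1CN(C(=O)[C@@H]2C[C@H](S(=O)(=O)c3ccccc3)C[C@H]2C(=O)NC2(C#N)CC2)C[C@H](C)O1` gives 0.4 nM, the lowest number among the three; its gap to compound 2 lies within the usual scatter of repeated measurements, while its gap to compound 1 lies far beyond it. Compound 4 `CC1CCN(C(=O)[C@@H]2C[C@H](S(=O)(=O)c3ccccc3)C[C@H]2C(=O)NC2(C#N)CC2)CC1` has not yet been measured. It differs from compound 3 in a single place: 4-methylpiperidin-1-yl in place of 2,6-dimethylmorpholin-4-yl on a carbonyl carbon. For the measured compounds named here, no pair of measured compounds shows this same change, so there is no direct precedent here for its effect, and the rest of the molecule, including the nitrile and the sulfonyl group, is kept as in compound 3. The step from compound 3 to compound 4 is expected to be small, with no clear direction and most likely within the scatter a 1.5-fold higher number from compound 3 to compound 4 (0.18 log units; within the scatter). In this assay compound 4 is expected to give about 0.6 nM, with a plausible range from 0.2 nM to 2 nM.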

Compound 4, half-maximal inhibitory concentration: 0.5 nM
Compound 4: the middle estimate sits 1.2-fold (0.08 log units) above what was measured; the measured number falls inside the stated range.
By their numbers in this assay, from the lowest: compounds 3, 2 and 4 (each within the scatter of the next); then compound 1.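

For the compounds shown here, this is the first pair of measured compounds that differ in one place. In this assay, placing 4-methylpiperidin-1-yl instead of 2,6-dimethylmorpholin-4-yl on the carbonyl carbon gives a 1.3-fold higher number from compound 3 to compound 4 (0.10 log units; within the scatter), so the two compounds cannot be told apart, and a group with no ring oxygen and no defined stereocentres serves as well here as one with both. Nothing available explains why the two groups read alike.

Going by these compounds, both groups are six-membered non-aromatic rings carrying methyl, so it stays open whether an open chain such as diethylamino, or a ring bearing a primary amine or a carboxylic acid, would keep the number this low on the same carbonyl carbon. On these data alone, it also stays open whether this swap would read the same on a molecule that otherwise matches compound 2.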